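The compounds below may be only part of what the source reports. "The series", "measured", "known", "first", "only" and "open" are said of these compounds alone.

Measured compounds in a functional assay on HeLa cells (Homo sapiens) for antiproliferative activity, read by MTT assay, with a stated time of 72 h; on this read-out higher numbers stand for weaker inhibition and lower numbers for stronger inhibition:
Compound 1 `O=c1cc(CC(O)(COCc2ccccc2)COCc2ccccc2)[nH]c(=O)[nH]1`: reported only as a limit, > 100000 nM.
Compound 2 `COCn1c(CC(O)(COCc2ccccc2)COCc2ccccc2)cc(=O)[nH]c1=O`: reported only as a limit, > 100000 nM.

For the measured compounds named here, compound 2 stands at the assay limit, so no number places it relative to anything else; the one further value shown beside it is a limit as well. The change from compound 1 to compound 2 is methoxymethyl in place of hydrogen on an aromatic nitrogen, and the step that the two limits leave unreadable from compound 1 to compound 2 cannot be read, since the limit of > 100000 nM in this assay, at which 2 of the 2 values shown sit, holds both values. Compound 3 `C[Si](C)(C)CCOCn1c(CC(O)(COCc2ccccc2)COCc2ccccc2)cc(=O)[nH]c1=O` differs from compound 2 by a group of 5 heavy atoms (4 carbon, 1 silicon; no ring) in place of a hydrogen atom, on a saturated chain carbon bound to an oxygen on a saturated carbon. Going by the values given here, the only measured step that could bear on this change is the one from compound 1 to compound 2, and its size is not readable. Among the compounds with values here, no measured step therefore gives a direction or a size for the step in this assay; the expectation is that compound 3 also returns only a limit. Compound 3 is expected at 150000 nM, range 50000 nM to 500000 nM, an estimated step that the limit leaves unreadable from compound 2 to compound 3.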

Compound 3, half-maximal inhibitory concentration: > 100000 nM
Compound 3 gave a limit, no number; the forecaster's own chance of this, stated with the estimate: 85%; the middle value lies beyond the limit too.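

No step among compound 1, compound 2 and compound 3 can be read in this assay, and all three are reported only as a limit, not a number: the limit of > 100000 nM in this assay, at which 3 of the 3 values shown sit.

The compounds shown leave open whether either group on the aromatic nitrogen changes antiproliferative activity at all, and in which direction.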